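The source may hold more compounds than are shown below. What is called first, only, known or untested is meant among the compounds shown, and "the series" means these compounds.

Measured compounds:
compound 1, `COc1cc(Nc2nc(Nc3ccc(Br)cc3)nnc2Cl)cc(OC)c1OC`, 11400 nM
compound 2, `COc1cc(Nc2nc(Nc3ccc(C)cc3)nnc2Cl)cc(OC)c1OC`, 19800 nM

Within the data shown here, compound 2 is one of only two compounds measured in a functional assay on MGC-803 cells (Homo sapiens) for inhibition, read by MTT assay, with a stated time of 48 h; on this read-out lower numbers stand for stronger inhibition and higher numbers for weaker inhibition; its number sits at the upper end of the pair, but the distance between the two is just a 1.7-fold higher number from compound 1 to compound 2 (0.24 log units; within the scatter), which is within the scatter, so the two cannot be told apart on these data.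

Compound 3, `COc1cc(Nc2nc(Nc3ccc(C(C)=O)cc3)nnc2Cl)cc(OC)c1OC`, carries acetyl in place of methyl on an aromatic carbon. Among the measured compounds shown here, the single measured step, bromo to methyl on the same aromatic carbon, was a 1.7-fold higher number from compound 1 to compound 2 (0.24 log units; within the scatter) and therefore says little: it shows that the two groups tried at this position behaved alike, but neither resembles acetyl, and no other change at this place has been measured. There is no basis for predicting a shift beyond the scatter in either direction, so compound 3 is expected to land near compound 2, with a broad uncertainty to allow for an untested group.

Compound 3 is estimated at 15000 nM, with a range from 5000 nM to 45000 nM, which means an expected step of a 1.3-fold lower number from compound 2 to compound 3 (0.12 log units; within the scatter).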

Compound 3, half-maximal inhibitory concentration: 13000 nM
For compound 3 the middle estimate is 1.2-fold (0.06 log units) above the measured one, within the range that was stated.
By their numbers in this assay, from the lowest: compounds 1, 3 and 2 (each within the scatter of the next).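

In this assay acetyl, which brings three heavy atoms, a double bond outside the aromatic ring and a hydrogen-bond acceptor in place of the single carbon of methyl, gives a 1.5-fold lower number from compound 2 to compound 3 (0.18 log units; within the scatter) and so cannot be told apart from methyl at this place, para to a large group. Set against bromo, acetyl gives a 1.1-fold higher number from compound 1 to compound 3 (0.06 log units; within the scatter) and again cannot be told apart, so three groups of different make-up on this aromatic carbon now lie within the scatter of one another, where the earlier pair offered only two. No evidence is available that bears on why these groups read alike.

The compounds shown leave open whether any group on this aromatic carbon moves the number beyond the scatter, and an amine, a carboxylic acid or a longer chain there would test that. They also leave open whether this flat reading holds for a group placed elsewhere on the ring, or with any other part of the shared core altered, since all three compounds keep the rest of the core unchanged.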